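From allyl to 4-methylbenzyl on the free acid

This account rests on a few compounds, and the source may have more. Where it says the series, first, only, none or still open, it means among the compounds named here.

- Compound 1 `CCOC(=O)c1c(C)nc(-c2cccc(C#N)c2)n1OCc1ccc(C)cc1`: 6310 nM
- Compound 2 `C=CCOn1c(-c2cccc(C#N)c2)nc(C)c1C(=O)O`: 6350 nM

Level with compound 1 within the scatter in a functional assay on a cell-free system (plasma, Oryctolagus cuniculus) for inhibition, with stated times of 5 min, 1 min and 6 min (on this read-out higher numbers stand for weaker inhibition and lower numbers for stronger inhibition), compound 2 gives 6350 nM. Compound 3 `Cc1ccc(COn2c(-c3cccc(C#N)c3)nc(C)c2C(=O)O)cc1` differs from compound 2 by 4-methylphenyl in place of vinyl on a saturated chain carbon bound to an oxygen on an aromatic ring. Among the compounds with values here, no measured pair isolates this change, and the values offer little guide, with compound 1 at 6310 nM not separated from compound 2. In this assay, the expected 2.1-fold lower number from compound 2 to compound 3 (0.33 log units; beyond the scatter) is modest, towards a lower number and only slightly beyond the scatter. For compound 3 the estimate is 3000 nM, with an expected range of 600 nM to 12000 nM.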

Compound 3, half-maximal inhibitory concentration: 6560 nM
For compound 3 the middle estimate is 2.2-fold (0.34 log units) below the measured one; the measured number falls inside the stated range.
By their numbers in this assay, from the lowest: compounds 1, 2 and 3 (each within the scatter of the next).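

On the saturated chain carbon bound to an oxygen on an aromatic ring, 4-methylphenyl in place of vinyl leaves the number in this assay unmoved, with a 1.0-fold higher number from compound 2 to compound 3 (0.01 log units; within the scatter). With 4-methylbenzyl in place, hydrogen in place of ethyl on an oxygen next to a carbonyl group is equally silent, with a 1.0-fold higher number from compound 1 to compound 3 (0.02 log units; within the scatter). Nothing available accounts for either result. On these data alone, each change is read on one background only, so its generality stays open. Also open, as far as these compounds go, is whether a longer chain bearing an amine, or an amide in place of the carboxylic acid, would move the number.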